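The source may report more compounds than this note shows. Statements on the series, on what has been measured and on what is new or still open speak of the compounds shown alone.

Compound 1 (`C[C@@H](Oc1cc2oc(=O)n(CCC(=O)O)c2cc1Cl)c1ccc(F)cn1`) gives 31 nm/s in a physicochemical assay for permeability, using PAMPA (on this read-out higher numbers stand for higher permeability and lower numbers for lower permeability), as a measured number. Compound 2 (`CC(C)Cc1cc2oc(=O)n(CCC(=O)O)c2cc1Cl`) gives < 10 nm/s in this assay and this is a limit. Compound 3 (`C[C@@H](Oc1cc2oc(=O)n(CCC(=O)O)c2cc1Cl)c1cccnn1`) gives < 3 nm/s in this assay and this too is a limit, not a number. For the measured compounds named here, the one measured step bearing on the next change is an at least 10-fold lower number from compound 1 to compound 3 (1.01 log units; beyond the scatter) and it is large, beyond the scatter. Compound 4 (`C[C@@H](Oc1cc2oc(=O)n(CCC(=O)O)c2cc1Cl)c1ncccn1`) differs from compound 3 by pyrimidin-2-yl in place of pyridazin-3-yl on a saturated chain carbon bound to an oxygen on an aromatic ring and a saturated chain carbon with pyrimidin-2-yl in place of pyridazin-3-yl and the same atoms joined differently. Going by the values given here, no measured step exchanges these two groups, so no step beyond the scatter is expected and the estimate is a number no lower from compound 3 to compound 4 (the limit leaves the size open) for this swap. Compound 4 is expected at 3 nm/s within a range of 1 nm/s to 10 nm/s on this estimate.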

Compound 4, apparent permeability: < 3 nm/s
Compound 4: only a limit was reported; the forecaster's own chance of this, stated with the estimate: 55%; the middle value lies on the limit itself.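

Pyrimidin-2-yl at this position gives an at least 10-fold lower number from compound 1 to compound 4 (1.01 log units; beyond the scatter) and so joins pyridazin-3-yl of compound 3 on the low side of compound 1. Compound 4 gives < 3 nm/s in this assay and this is a limit. The steps between compound 3 and compound 4 cannot be read, and the two ring arrangements stay unseparated: the limit of < 3 nm/s in this assay, at which 2 of the 4 values shown sit.

Open, from the compounds shown here alone, is whether the step from compound 1 follows the ring nitrogens or the fluorine. Plain pyridin-2-yl or phenyl on this carbon would separate the two.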